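Swapping the pendant aryl of compound 3 for a dimethylphenyl

This account rests on a few compounds, and the source may have more. Where it says the series, first, only, none or still open, it means among the compounds named here.

Three compounds share one core and differ only in the aryl group hanging from it. In an ADME assay on MT4 cells (Homo sapiens) for cytotoxicity, read by MTT assay, with a stated time of 4 days (on this read-out lower numbers stand for higher toxicity in this test and higher numbers for lower toxicity in this test), compound 1 `COc1ccccc1-c1cc(C)c(Nc2ccnc(Nc3ccc(C#N)cc3)n2)c(C)c1` gives 940 nM, compound 2 `Cc1cc(-c2ccccc2C(F)(F)F)cc(C)c1Nc1ccnc(Nc2ccc(C#N)cc2)n1` gives 4210 nM, and compound 3 `Cc1cc(-c2cc(Cl)cc(Cl)c2)cc(C)c1Nc1ccnc(Nc2ccc(C#N)cc2)n1` gives 4290 nM. Compound 3 thus shows the highest number of the three, though its value and that of compound 2 are within the scatter of each other. Compound 4 `Cc1cc(-c2c(C)cccc2C)cc(C)c1Nc1ccnc(Nc2ccc(C#N)cc2)n1` differs from compound 3 by 2,6-dimethylphenyl in place of 3,5-dichlorophenyl on an aromatic carbon. Among the compounds with values here, two measured steps bear on such an aryl swap: a 4.6-fold higher number from compound 1 to compound 3 (0.66 log units; beyond the scatter) and a 1.0-fold higher number from compound 2 to compound 3 (0.01 log units; within the scatter). So one exchange of this group moved the number modestly, the other not at all. A step of a 1.4-fold lower number from compound 3 to compound 4 (0.16 log units; within the scatter) is therefore expected, that is, little or no change beyond the scatter in this assay. Compound 4 is estimated to give 3000 nM, with a range from 1000 nM to 9000 nM.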

Compound 4, half-maximal cytotoxic concentration: 2590 nM
Compound 4: middle estimate off by 1.2-fold (0.06 log units), on the high side; low and high end bracket the measured number.
By their numbers in this assay, from the lowest: compound 1; then compounds 4, 2 and 3 (each within the scatter of the next).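

In this assay the step to the 2,6-dimethylphenyl group gives a 1.7-fold lower number from compound 3 to compound 4 (0.22 log units; within the scatter) and a 1.6-fold lower number from compound 2 to compound 4 (0.21 log units; within the scatter), both within the scatter, while a 2.8-fold higher number from compound 1 to compound 4 (0.44 log units; beyond the scatter) lies beyond it. Aryl groups carrying trifluoromethyl, chlorine or methyl therefore cannot be told apart in this test, and among these four compounds only compound 1, with its 2-methoxyphenyl group, stands apart, with the lowest number and so the highest toxicity in this test. No measurement is available that explains this difference.

From the compounds shown here alone, it remains open whether another oxygen-bearing group on the pendant ring, such as ethoxy or hydroxyl, would give a number like that of compound 1. Going by these compounds, how an amine or a carboxylic acid on that ring would read in this test also remains open.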